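A Fluoropyridine in Place of Fluorophenyl on the Core

This account rests on a few compounds, and the source may have more. Where it says the series, first, only, none or still open, it means among the compounds named here.

Compound 1 `COc1ccc(-n2cnc3cnc(-c4ccc(F)cc4C)cc32)cc1`: 6 nM
Compound 2 `Fc1ccc(-c2cc3c(cn2)ncn3-c2ccc(OC(F)F)cc2)cc1`: 10000 nM

Of the compounds shown here, two have been measured in a functional assay on HL-60 cells (Homo sapiens) for activation, read by flow cytometry, with a stated time of 4 days; on this read-out lower numbers stand for an effect already at smaller amounts and higher numbers for an effect only at larger amounts of compound. Compound 1 gives 6 nM in this assay, whereas compound 2 gives 10000 nM, the highest of the two numbers and a gap from compound 1 that lies well beyond the usual scatter. Compound 3 `Cc1cc(F)ncc1-c1cc2c(cn1)ncn2-c1ccc(OC(F)F)cc1` has not yet been measured. It differs from compound 2 in one place: a group of 8 heavy atoms (6 carbon, 1 nitrogen, 1 fluorine; one six-membered aromatic ring with 1 hetero atom) in place of a group of 7 heavy atoms (6 carbon, 1 fluorine; one six-membered aromatic ring of carbon only), on an aromatic carbon. Among the compounds with values here, no pair of measured compounds isolates this change, so the expectation rests only on the two values at hand. Since compound 2 stands at the top and compound 1 far below it, a step toward lower numbers, beyond the scatter, is expected. The step from compound 2 to compound 3 is estimated as a 170-fold lower number from compound 2 to compound 3 (2.22 log units; beyond the scatter). Compound 3 is expected to give 60 nM in this assay, within a range from 6 nM to 600 nM.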

Compound 3, half-maximal effective concentration: 1200 nM
Beside the measured number, compound 3's estimate is 20-fold (1.30 log units) below it, and the stated range ends below it.
By their numbers in this assay, from the lowest: compound 1; then compound 3; then compound 2.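

In this assay, within the data shown here, this pair gives the first reading of a single change on the aromatic carbon next to the ring nitrogen: replacing 4-fluorophenyl with the new ring gives an 8.3-fold lower number from compound 2 to compound 3 (0.92 log units; beyond the scatter) and thus a modest but real shift on the read-out. The change is a bundled one, as the entering group brings a ring nitrogen, one hydrogen-bond acceptor and one more carbon all at once. Nothing at hand explains the step.

The compounds shown leave open which of these differences carries the step, since no compound separates the ring nitrogen from the added carbon. They also leave open how this position would respond to a ring bearing an amine or a nitrile in place of the fluorine.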